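Bromo for nitro on a caffeic-type ester

The compounds below may be only part of what the source reports. "The series", "measured", "known", "first", "only" and "open" are said of these compounds alone.

Measured so far: compound 1 `CC1(C)C2CCC1(C)C(OC(=O)/C=C/c1cc(O)c(O)c(Cl)c1)C2` gives 69500 nM; compound 2 `CC1(C)C2CCC1(C)C(OC(=O)/C=C/c1ccc(O)c(O)c1[N+](=O)[O-])C2` gives "not determined" (no result reported); compound 3 `O=C(/C=C/c1cc(O)c(O)c([N+](=O)[O-])c1)OCCc1ccccc1` gives "not determined" (no result reported).

In a functional assay on SGC-7901 cells (Homo sapiens) for inhibition, read by MTT assay (a lower number here means a stronger inhibitor, a higher number a weaker inhibitor), only compound 1 has a number, and it is a weak one. Among the compounds with values here, compound 3 stands without a number, as does compound 2, so no step between measured compounds can be drawn from this set. The step to compound 4 `O=C(/C=C/c1cc(O)c(O)c(Br)c1)OCCc1ccccc1` is bromo in place of nitro on an aromatic carbon. With compound 1 the only anchor, a step about as large as the scatter is expected in either direction, with weak inhibition remaining the likely outcome. Compound 4 is estimated at 50000 nM in this assay, within a range of 12000 nM to 200000 nM.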

Compound 4, half-maximal inhibitory concentration: 6750 nM
Compound 4: the middle estimate sits 7.4-fold (0.87 log units) above what was measured; the measured number lies below the stated range.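

Within the data shown here, compound 3 has no single number in this assay, so no step to compound 4 can be read. Whether bromo in place of nitro changes inhibition stays open, and no evidence on any cause is available.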